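Removing the second methoxy from compound 3

A few compounds are considered here, and "the series" means these few. Any claim that something is new, unique, unknown or untested is made for them only; others in the source may bear on it.

Measured in an ADME assay on RAW264.7 cells (Mus musculus) for cytotoxicity, read by MTT assay, with a stated time of 24 h, tested at 10 ug/mL; on this read-out lower numbers stand for a stronger effect and higher numbers for a weaker effect at the one concentration tested:
- compound 1, `COc1ccc(/C=C/C(=O)c2cccc(O)c2)c(OC)c1`: 61.6%
- compound 2, `COc1ccc(CCCc2cccc(O)c2)c(OC)c1`: 67.9%
- compound 3, `COc1ccc(C(=O)CCc2ccc(OC)cc2OC)c(O)c1`: 83.4%

Compound 3 gives the highest number of the three in this assay, which on this read-out is the weakest effect. Its nearest neighbour is compound 2, whose number is lower by a margin beyond the scatter; compound 1 lies furthest away, lower again by a margin beyond the scatter. For the measured compounds named here, no pair among the measured compounds differs in a single place, so no single step is available to calibrate what one change does here.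

Compound 4, `COc1ccc(CCC(=O)c2ccc(OC)cc2O)cc1`, has not yet been measured in this assay. Compared with compound 3 the change is hydrogen in place of methoxy on an aromatic carbon.

Going by the values given here, with no measured single-place step on record, the expectation rests on the value of compound 3 alone, 83.4%, taken as the anchor. The step expected here, a number 5.4 percentage points lower from compound 3 to compound 4 (within the scatter), is estimated to be small, most likely within the scatter of the assay, with a slight lean towards a lower number. Compound 4 is therefore expected to give about 78% in this assay, in the range 62% to 92%.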

Compound 4, a percentage reported as activity, at one concentration (the size of the read-out at that concentration, not a potency): 88%
Compound 4: the middle estimate sits 10 percentage points below what was measured; measured number inside the range.
By their numbers in this assay, from the lowest: compounds 1 and 2 (each within the scatter of the next); then compounds 3 and 4 (each within the scatter of the next).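

In this assay, the series now has its first single-place step, a number 4.6 percentage points higher from compound 3 to compound 4 (within the scatter), with hydrogen in place of methoxy on an aromatic carbon ortho to a large group and meta to a methoxy group. This read-out therefore does not separate methoxy from hydrogen at this position, so the loss of 2 heavy atoms and 1 hydrogen-bond acceptor leaves no change that can be told from the scatter. The earlier compounds differed in more than one place and could not show this, but the new step provides a size for this one change only, and no supporting measurement is available to explain the result.

As far as these compounds go, whether an amine or a carboxylic acid on this aromatic carbon would also stay within the scatter of compound 4 remains open, and a group of that kind would test whether this position tolerates more than the exchange of methoxy and hydrogen. Also open, from the compounds shown here alone, is whether the same exchange at another place on the shared core would give a step of similar size in this assay, since this single step says nothing about other positions.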